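Compound 4: Cyclohexylphenyl Exchanged for Cyclohexylpyrazinyl

The source may hold more compounds than are shown below. What is called first, only, known or untested is meant among the compounds shown, and "the series" means these compounds.

Measured compounds:
Compound 1 `O=C(O)c1ccc(N(Cc2ccc(C3CCCCC3)cc2)C(=O)[C@H]2CCN2S(=O)(=O)c2c(F)c(F)c(F)c(F)c2F)c(F)c1`: in a functional assay on MDA-MB-231 cells (Homo sapiens) for antiproliferative activity, with a stated time of 72 h (on this read-out higher numbers stand for an effect only at larger amounts of compound and lower numbers for an effect already at smaller amounts), compound 1 gives > 10000 nM, which is a limit of the assay and not a number.
Compound 2 `COC(=O)c1ccc(N(Cc2ccc(C3CCCCC3)cc2)C(=O)[C@H]2CCN2S(=O)(=O)c2c(F)c(F)c(F)c(F)c2F)cc1O`: in this assay compound 2 gives 2700 nM.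
Compound 3 `COC(=O)c1ccc(N(Cc2ccc(C3CCCCC3)cc2)C(=O)[C@H]2CCN2S(=O)(=O)c2c(F)c(F)c(F)c(F)c2F)c(F)c1`: in this assay compound 3 gives 4400 nM.

Among the compounds with a number, compound 3 sits highest, but its gap to compound 2, a 1.6-fold higher number from compound 2 to compound 3 (0.21 log units; within the scatter), is within the scatter, so the two cannot be ordered. For the measured compounds named here, the only steps beyond the scatter are an at least 3.7-fold lower number from compound 1 to compound 2 (0.56 log units; beyond the scatter) and an at least 2.2-fold lower number from compound 1 to compound 3 (0.35 log units; beyond the scatter), and both start from a limit, as noted in the limit of > 10000 nM in this assay, at which 1 of the 3 values shown sits.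

Compound 4 `COC(=O)c1ccc(N(Cc2cnc(C3CCCCC3)cn2)C(=O)[C@H]2CCN2S(=O)(=O)c2c(F)c(F)c(F)c(F)c2F)c(F)c1` carries the change (5-cyclohexylpyrazin-2-yl in place of 4-cyclohexylphenyl on a saturated chain carbon bound to an amide-type nitrogen). Going by the values given here, none of the measured steps touches this part of the molecule: all three concern the aryl group on the amide-type nitrogen or the ester. Among the compounds with values here, there is therefore no measured step that bears directly on the exchange of the cyclohexylphenyl group for the cyclohexylpyrazinyl group.

With no guidance from the data, compound 4 is expected to stay close to compound 3, with a step of a 1.1-fold higher number from compound 3 to compound 4 (0.06 log units; within the scatter) that lies within the scatter. Compound 4 is estimated at 5000 nM, within the range 1500 nM to 15000 nM.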

Compound 4, half-maximal effective concentration: 1400 nM
For compound 4 the middle estimate is 3.6-fold (0.55 log units) above the measured one; measured number outside the range, below it.
By their numbers in this assay, from the lowest: compounds 4, 2 and 3 (each within the scatter of the next, the first and the last beyond it). At a limit, above all of these: compound 1.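

For the compounds shown here, the exchange of 4-cyclohexylphenyl for 5-cyclohexylpyrazin-2-yl on a saturated chain carbon bound to an amide-type nitrogen gives the first readable result for this part of the molecule: in this assay there is a 3.1-fold lower number from compound 3 to compound 4 (0.50 log units; beyond the scatter), and unlike the earlier steps beyond the scatter, this one does not start from a limit. Both groups hold 12 heavy atoms and keep the cyclohexyl ring, so the change lies in the aromatic ring, which now has 2 hetero atoms and brings 2 hydrogen-bond acceptors where the old group had 0. Nothing measured here tells which feature of this exchange lies behind the step.

As far as these compounds go, it remains open how a pyridine ring carrying the cyclohexyl group in the same place would compare, which would show whether a single ring nitrogen gives a similar step. Also open, from the compounds shown here alone, is whether this exchange would bring the carboxylic acid compound 1 into a readable range, as compound 1 gives > 10000 nM, which is a limit of the assay and not a number.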